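This account rests on a few compounds, and the source may have more. Where it says the series, first, only, none or still open, it means among the compounds named here.

Going by the values given here, the three compounds measured so far share one core and differ only in the group on a saturated chain carbon bound to a sulfur. In a functional assay on MGC-803 cells (Homo sapiens) for inhibition, read by MTT assay, with a stated time of 72 h (a lower number here means a stronger inhibitor, a higher number a weaker inhibitor), compound 1 `Cc1cc(N2CC[C@@H](C)[C@@H](N(C)c3ncnc4[nH]ccc34)C2)n2nc(SCC3CC3)nc2n1` gives 9540 nM. Compound 2 `Cc1cc(N2CC[C@@H](C)[C@@H](N(C)c3ncnc4[nH]ccc34)C2)n2nc(SCc3nc4ccccc4[nH]3)nc2n1` gives 21200 nM, the higher of the two numbers given, after the step of a 2.2-fold higher number from compound 1 to compound 2 (0.35 log units; beyond the scatter). Compound 3 `Cc1cc(N2CC[C@@H](C)[C@@H](N(C)c3ncnc4[nH]ccc34)C2)n2nc(SCc3csc4ccc(Cl)cc34)nc2n1` reaches only a limit of this assay, > 100000 nM; this is the limit (the limit of > 100000 nM in this assay, at which 1 of the 3 values shown sits). Compound 4 `CCCSc1nc2nc(C)cc(N3CC[C@@H](C)[C@@H](N(C)c4ncnc5[nH]ccc45)C3)n2n1` is not yet measured; it differs from compound 2 by ethyl in place of 1H-benzimidazol-2-yl on a saturated chain carbon bound to a sulfur. Among the compounds with values here, the one comparable step, a 2.2-fold higher number from compound 1 to compound 2 (0.35 log units; beyond the scatter), went in the opposite direction, a small group at that carbon giving the lower number, so a modest step downward is expected. Compound 4 is expected to give 10000 nM, in the range 4000 nM to 25000 nM. The expected step is a 2.1-fold lower number from compound 2 to compound 4 (0.33 log units; beyond the scatter).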

Compound 4, half-maximal inhibitory concentration: 15500 nM
For compound 4 the middle estimate is 1.6-fold (0.19 log units) below the measured one, within the range that was stated.
By their numbers in this assay, from the lowest: compounds 1, 4 and 2 (each within the scatter of the next, the first and the last beyond it). At a limit, above all of these: compound 3.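

In this assay, ethyl and 1H-benzimidazol-2-yl on this saturated chain carbon cannot be separated, a 1.4-fold lower number from compound 2 to compound 4 (0.14 log units; within the scatter), so the fused aromatic group and its hydrogen-bond donor are not required for this level of activity. Ethyl and cyclopropyl cannot be separated either, a 1.6-fold higher number from compound 1 to compound 4 (0.21 log units; within the scatter). Only 5-chloro-1-benzothiophen-3-yl stands apart, an at least 6.4-fold lower number from compound 3 to compound 4 (0.80 log units; beyond the scatter), and that step rests on a limit for compound 3: the limit of > 100000 nM in this assay, at which 1 of the 4 values shown sits.

As far as these compounds go, whether that gap follows from the chlorine or from the benzothiophene itself remains open. So does what an amine or a carboxylic acid at this carbon would give.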